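Exchanging the Nitrooxy End for a Cyano-Oxadiazole

The source may report more compounds than this note shows. Statements on the series, on what has been measured and on what is new or still open speak of the compounds shown alone.

Among the measured compounds shown here, in a functional assay (aorta) with Rattus norvegicus as the target, in the presence of a further agent that is not named here (on this read-out lower numbers stand for an effect already at smaller amounts and higher numbers for an effect only at larger amounts of compound), compound 1 `COC(=O)C1=C(C)N=C(C)/C(=C(/O)OC)C1c1ccccc1OCCO[N+](=O)[O-]` gives 56 nM, the lower of the two numbers known so far. Compound 2 `COC(=O)C1=C(C)N=C(C)/C(=C(/O)OC)C1c1cccc(OCCO[N+](=O)[O-])c1` gives 750 nM, and the gap between the two lies beyond the usual scatter. Compound 3 `COC(=O)C1=C(C)N=C(C)/C(=C(/O)OC)C1c1ccccc1OCc1nonc1C#N` has not yet been measured. It departs from compound 1 by one exchange, 4-cyano-1,2,5-oxadiazol-3-yl in place of (nitrooxy)methyl on a saturated chain carbon bound to an oxygen on an aromatic ring: 4-cyano-1,2,5-oxadiazol-3-yl stands in place of (nitrooxy)methyl on a saturated chain carbon bound to an oxygen on an aromatic ring. For the measured compounds named here, no measured pair shows this exchange, so the expectation is uncertain. With compound 1 at 56 nM as the low end of the known numbers, a change there is expected to raise the number rather than lower it. The estimated step is moderate but beyond the scatter, a 3.6-fold higher number from compound 1 to compound 3 (0.55 log units; beyond the scatter). In this assay, compound 3 is expected at 200 nM, with an estimated range of 40 nM to 1000 nM.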

Compound 3, half-maximal effective concentration: 6.6 nM
For compound 3 the middle estimate is 30-fold (1.48 log units) above the measured one; measured number below the stated range.
By their numbers in this assay, from the lowest: compound 3; then compound 1; then compound 2.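

In this assay, the exchange of (nitrooxy)methyl for 4-cyano-1,2,5-oxadiazol-3-yl gives an 8.5-fold lower number from compound 1 to compound 3 (0.93 log units; beyond the scatter), so the low end set by compound 1 was not the floor for this position. The two earlier compounds both carried the 2-(nitrooxy)ethoxy group, and compound 3 shows that a low number here does not depend on it: a (4-cyano-1,2,5-oxadiazol-3-yl)methoxy group, with its five-membered aromatic ring and nitrile, does better on this read-out. Nothing available explains why the number falls with this exchange.

From the compounds shown here alone, it remains open whether the nitrile itself matters, since a carboxylic acid or an amide in its place would separate its share from that of the ring. Also open, going by these compounds, is whether a longer chain to the ring would keep the gain, and whether the same exchange would lower the number on the core of compound 2.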